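Three Cell-Growth Inhibitors and an Untested Relative

The compounds below may be only part of what the source reports. "The series", "measured", "known", "first", "only" and "open" are said of these compounds alone.

Of the compounds shown here, three have been tested in a functional assay on A549 cells (Homo sapiens) for cytotoxicity, with a stated time of 48 h; on this read-out lower numbers stand for stronger inhibition and higher numbers for weaker inhibition. Compound 1 `COc1cccc2c(=O)cc(/C=C/[S+](C)[O-])oc12` gives 2200 nM, and compound 2 `COc1ccc2c(=O)cc(/C=C/[S+](C)[O-])oc2c1` gives 2200 nM. Compound 3 `CC(C)COc1ccc2oc(/C=C/[S+](C)[O-])cc(=O)c2c1` gives 1100 nM. Compound 3 carries the lowest of the three numbers, yet its gaps to compound 1 and to compound 2 both fall within the usual scatter of repeated measurements, so the three cannot be told apart with confidence on these data.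

Compound 4 `CC(=O)Oc1ccc2oc(/C=C/[S+](C)[O-])cc(=O)c2c1` has not yet been measured. It differs from compound 3 in one place: acetyl in place of isobutyl on an oxygen on an aromatic ring. Going by the values given here, no measured pair here shows what swapping isobutyl for acetyl on that oxygen does to the read-out, and the three measured numbers sit close together. The expected change is therefore small, a 1.4-fold higher number from compound 3 to compound 4 (0.13 log units; within the scatter), with no direction that can be trusted beyond the scatter. Compound 4 is estimated to give 1500 nM in this assay, within a range from 600 nM to 4000 nM.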

Compound 4, half-maximal inhibitory concentration: 4100 nM
For compound 4 the middle estimate is 2.7-fold (0.44 log units) below the measured one; the measured number lies above the stated range.
By their numbers in this assay, from the lowest: compounds 3, 1, 2 and 4 (each within the scatter of the next, the first and the last beyond it).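

Swapping isobutyl for acetyl on an oxygen on an aromatic ring gives, in this assay, a 3.7-fold higher number from compound 3 to compound 4 (0.57 log units; beyond the scatter) and is the first single-place change that can be read in this set. Going by these compounds alone, it shows that the read-out responds to the group on this oxygen, something the earlier compounds could not reveal, since their numbers all lay within the scatter of one another and no two of them formed such a pair. Nothing available explains why the number rises with this change.

With only isobutyl and acetyl compared on this oxygen, the shown compounds leave open whether the carbonyl of the acetyl or the loss of the isobutyl chain accounts for the step. They also leave open how a longer chain, a free hydroxyl or an amine-bearing chain at this place would read.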